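The source may hold more compounds than are shown below. What is called first, only, known or untested is meant among the compounds shown, and "the series" means these compounds.

Measured so far:
- compound 1 `C#CC(C)OC(=O)c1ccc(C(CC)(CC)c2ccc(OCCC(O)(CC)CC)c(C)c2)n1CC`: 14800 nM
- compound 2 `CCn1c(C(=O)NC(C)C(=O)O)ccc1C(CC)(CC)c1ccc(OCCC(O)(CC)CC)c(C)c1`: 11700 nM

In a functional assay on PC-3 cells (Homo sapiens) for antiproliferative activity, read by MTT assay, with a stated time of 48 h (on this read-out higher numbers stand for weaker inhibition and lower numbers for stronger inhibition), compound 1 gives 14800 nM, the highest of the two numbers, with compound 2 nearest at 11700 nM. Within the data shown here, the only measured step, a 1.3-fold lower number from compound 1 to compound 2 (0.10 log units; within the scatter), shows that exchanging the ester for an amide on the carbonyl carbon leaves the read-out within the scatter. Compound 3 `CCC(C)C(CO)NC(=O)c1ccc(C(CC)(CC)c2ccc(OCCC(O)(CC)CC)c(C)c2)n1CC` differs from compound 1 by (1-(hydroxymethyl)-2-methylbutyl)amino in place of (1-methylprop-2-yn-1-yl)oxy on a carbonyl carbon. Among the measured compounds shown here, the step to compound 2 bears on this as the only comparison of an amide against the ester at the same carbonyl carbon; on that basis compound 3 is expected to move little, if at all, beyond the scatter, a 1.3-fold lower number from compound 1 to compound 3 (0.13 log units; within the scatter). Compound 3 is therefore estimated at 11000 nM, within 4500 nM to 28000 nM.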

Compound 3, half-maximal inhibitory concentration: 28400 nM
Beside the measured number, compound 3's estimate is 2.6-fold (0.41 log units) below it; measured number outside the range, above it.
By their numbers in this assay, from the lowest: compounds 2, 1 and 3 (each within the scatter of the next, the first and the last beyond it).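

In this assay, the change from ester to this amide stays unresolved, a 1.9-fold higher number from compound 1 to compound 3 (0.28 log units; within the scatter). Among these compounds, the nitrogen substituent on the amide does register, a 2.4-fold higher number from compound 2 to compound 3 (0.39 log units; beyond the scatter), giving the first step beyond the scatter, though a modest one, and it separates two amides rather than an amide from the ester. No data on hand explain this difference.

Open, on these data alone, is whether a carboxylic acid directly on that carbonyl carbon, or a longer chain on the amide-type nitrogen, would shift the number further.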